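From 4-chlorophenyl to pyridin-2-yl on an amide-type nitrogen

This account rests on a few compounds, and the source may have more. Where it says the series, first, only, none or still open, it means among the compounds named here.

Values measured in a functional assay on KB cells (Homo sapiens) for antiproliferative activity, read by MTT assay, with a stated time of 48 h; on this read-out lower numbers stand for stronger inhibition and higher numbers for weaker inhibition:
Compound 1 `Cn1cc(C2=C(c3nn(CCCn4cncn4)c4ncccc34)C(=O)NC2=O)c2ccccc21`: > 100000 nM, a limit
Compound 2 `Cn1cc(C2=C(c3nn(CCCN4CCCCC4)c4ncccc34)C(=O)N(c3ccccc3)C2=O)c2ccccc21`: 5600 nM
Compound 3 `Cn1cc(C2=C(c3nn(CCCN4CCCCC4)c4ncccc34)C(=O)N(c3ccc(Cl)cc3)C2=O)c2ccccc21`: > 100000 nM, a limit

In this assay compound 3 stands at > 100000 nM, which is a limit and not a number. For the measured compounds named here, the series so far is marked by the limit of > 100000 nM in this assay, at which 2 of the 3 values shown sit. Only compound 2 gives a number, 5600 nM.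

Compound 4 `Cn1cc(C2=C(c3nn(CCCN4CCCCC4)c4ncccc34)C(=O)N(c3ccccn3)C2=O)c2ccccc21` has not yet been measured. It differs from compound 3 by pyridin-2-yl in place of 4-chlorophenyl on an amide-type nitrogen in a ring. Going by the values given here, the one measured step that bears on this change is an at least 17-fold higher number from compound 2 to compound 3 (1.25 log units; beyond the scatter), where chloro took the place of hydrogen on an aromatic carbon. Compound 4 carries no chloro, and neither does compound 2 at 5600 nM, so a lower number than for compound 3 is expected, possibly a large step but probably smaller than that one. Among the compounds with values here, no measured compound carries pyridin-2-yl, so this expectation is loose, and compound 4 may also end at the limit. The estimated move is an at least 8.3-fold lower number from compound 3 to compound 4 (0.92 log units; beyond the scatter). The estimated value in this assay for compound 4 is 12000 nM, with an expected range of 2500 nM to 100000 nM.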

Compound 4, half-maximal inhibitory concentration: > 100000 nM
Compound 4 ended at the assay's limit; the forecaster's own chance of this, stated with the estimate: 35%; middle value at least 8.3-fold (0.92 log units) from the limit.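

In this assay, pyridin-2-yl in place of phenyl on the amide-type nitrogen in a ring gives an at least 17-fold higher number from compound 2 to compound 4 (1.25 log units; beyond the scatter). The number seen for compound 2 is therefore lost not only when a chloro is added to the phenyl ring, as in compound 3, but also when a ring carbon is exchanged for nitrogen, so two different changes to this group now end at the same limit, and compound 2 remains the only compound shown with a number. The step from compound 3 to compound 4 cannot be read, as both values are limits and not numbers, and the series now stands as follows: the limit of > 100000 nM in this assay, at which 3 of the 4 values shown sit.

Going by these compounds, it remains open whether any other group on this nitrogen, such as pyridin-3-yl, 4-methoxyphenyl, benzyl or methyl, would keep a number or improve on compound 2. Nor do the compounds shown tell what the amide hydrogen alone would give with the piperidine-bearing chain, as compound 1 also differs from the others in that chain.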